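A few compounds are considered here, and "the series" means these few. Any claim that something is new, unique, unknown or untested is made for them only; others in the source may bear on it.

Compound 1 `COc1ccc(-n2cc(COc3cccc(NC(=O)Nc4ccc(Cl)c(C(F)(F)F)c4)c3)nn2)cc1` is the starting point of this step. In a functional assay on HepG2 cells (Homo sapiens) for inhibition, read by MTT assay, with a stated time of 72 h (on this read-out lower numbers stand for stronger inhibition and higher numbers for weaker inhibition), compound 1 gives 4680 nM, which is the second highest of the three numbers measured; its nearest neighbour is compound 2 and its furthest is compound 3. Compound 2 `Cc1ccc(-n2cc(COc3cccc(NC(=O)Nc4ccc(Cl)c(C(F)(F)F)c4)c3)nn2)cc1` carries a methyl in place of the methoxy and gives 5430 nM in this assay, a change of a 1.2-fold higher number from compound 1 to compound 2 (0.06 log units; within the scatter). Compound 3 `N#Cc1cccc(-n2cc(COc3cccc(NC(=O)Nc4ccc(Cl)c(C(F)(F)F)c4)c3)nn2)c1` carries a 3-cyanophenyl in place of the 4-methoxyphenyl on the aromatic nitrogen and gives 2760 nM in this assay, so that the step is a 1.7-fold lower number from compound 1 to compound 3 (0.23 log units; within the scatter), and from the methyl compound it is a 2.0-fold lower number from compound 2 to compound 3 (0.29 log units; within the scatter).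

Compound 4 `N#Cc1ccc(-n2cc(COc3cccc(NC(=O)Nc4ccc(Cl)c(C(F)(F)F)c4)c3)nn2)cc1` is the next member, not yet measured in this assay. It differs from compound 1 by cyano in place of methoxy on an aromatic carbon, cut one bond further out a 4-methoxyphenyl becoming a 4-cyanophenyl. All three known steps sit within the scatter, and the only one introducing a cyano, from compound 1 to compound 3, points toward a somewhat lower number. The step from compound 1 to compound 4 is therefore expected to be small, a 1.4-fold lower number from compound 1 to compound 4 (0.15 log units; within the scatter), with a lean toward a lower number but nothing beyond the scatter. Compound 4 is estimated to give 3300 nM in this assay, within a range of 1500 nM to 7000 nM.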

Compound 4, half-maximal inhibitory concentration: 2980 nM
Compound 4: the middle estimate sits 1.1-fold (0.04 log units) above what was measured; the range from low to high includes it.
By their numbers in this assay, from the lowest: compounds 3, 4, 1 and 2 (each within the scatter of the next).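

In this assay the position on the aromatic carbon para to a large group now carries three different groups, and swapping in the cyano leaves every step within the scatter: methoxy to cyano gives a 1.6-fold lower number from compound 1 to compound 4 (0.20 log units; within the scatter) and methyl to cyano gives a 1.8-fold lower number from compound 2 to compound 4 (0.26 log units; within the scatter), so compounds 1, 2 and 4 cannot be told apart at this position. Within the data shown here, compound 4 also forms the first pair in which the nitrile itself stays and only its place on the phenyl ring differs, and 4-cyanophenyl in place of 3-cyanophenyl gives a 1.1-fold higher number from compound 3 to compound 4 (0.03 log units; within the scatter), which leaves compounds 3 and 4 equally indistinguishable. Nothing available offers an explanation for why these steps remain this small.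

On these data alone, whether any group at this position can carry the number beyond the scatter remains open, since methoxy, methyl and cyano do not, and an amine, a carboxylic acid or a longer chain such as butoxy could test this. All four compounds also share the rest of the core of compound 1, so they say nothing about how much a change elsewhere in the structure would matter in this assay, or whether the small steps seen here would hold on a different core.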